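Series notes: a coumarin set in the rat MAO-A assay

The compounds below may be only part of what the source reports. "The series", "measured", "known", "first", "only" and "open" are said of these compounds alone.

Measured so far:
compound 1 `CCCOc1cc(=O)oc2cc(OCc3ccccc3)ccc12` — 0%
compound 2 `O=C(O)COc1cc(=O)oc2cc(OCc3cccc(Cl)c3)ccc12` — 0%

In an assay on isolated protein (strain Sprague-Dawley) for inhibition of Amine oxidase [flavin-containing] A (Rattus norvegicus), read by spectrophotometry, with a stated time of 5 min, tested at 10 uM (on this read-out higher numbers stand for more inhibition at the one concentration tested (going by the name of the read-out) and lower numbers for less inhibition), compound 1 gives 0% and compound 2 gives 0%. Compound 2 stands level with compound 1 at the digits shown; the two values are within the scatter of each other.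

Compound 3 `NC(=O)c1cc(=O)oc2cc(OCc3cccc(Cl)c3)ccc12` is not yet measured. It differs from compound 2 in one place: carbamoyl in place of carboxymethoxy on an aromatic carbon. For the measured compounds named here, no measured pair covers this change, so its size is unknown. With both measured compounds showing no inhibition, a small upward step is expected at most, as a number 10 percentage points higher from compound 2 to compound 3 (within the scatter). For compound 3 the estimated inhibition in this assay is 10%, within 0% to 40%.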

Compound 3, a percentage reported as inhibition, at one concentration (the size of the read-out at that concentration, not a potency): 14%
Beside the measured number, compound 3's estimate is 4 percentage points below it; measured number inside the range.
By their numbers in this assay, from the lowest: compounds 1 and 2 (each within the scatter of the next); then compound 3.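

With carbamoyl in place of carboxymethoxy, this assay shows a number 14 percentage points higher from compound 2 to compound 3 (beyond the scatter) on an aromatic carbon opposite the ring oxygen. The read-out at this position therefore responds to the group placed there, which the earlier pair, level within the scatter, could not show. No available data bear on the reason for this step.

From the compounds shown here alone, whether a nitrile or an amine on this carbon would raise inhibition further remains open. So does whether carbamoyl gives a similar step on the core of compound 1.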